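Trifluoromethyl for chloro on the urea aryl of compound 2

The source may report more compounds than this note shows. Statements on the series, on what has been measured and on what is new or still open speak of the compounds shown alone.

Compound 2 `O=C(Nc1cccc(-n2cc(-c3ccncc3)c(-c3ccc(Cl)c(O)c3)n2)c1)Nc1ccc(Cl)c(Cl)c1` gives 10600 nM in a functional assay on NCI-H522 cells (Homo sapiens) for inhibition, read by sulforhodamine B assay, with a stated time of 48 h (on this read-out lower numbers stand for stronger inhibition of growth and higher numbers for weaker inhibition of growth), and stands second highest of the three numbers shown: compound 3 `COc1cc(-c2nn(-c3cccc(NC(=O)c4ccc(Cl)c(C(F)(F)F)c4)c3)cc2-c2ccncc2)ccc1Cl` gives 13400 nM, within the scatter of it, while compound 1 `COc1cc(-c2nn(-c3cccc(NC(=O)Nc4ccc(Cl)c(Cl)c4)c3)cc2-c2ccncc2)ccc1Cl` gives 3100 nM, beyond the scatter. Compound 4 `O=C(Nc1cccc(-n2cc(-c3ccncc3)c(-c3ccc(Cl)c(O)c3)n2)c1)Nc1ccc(Cl)c(C(F)(F)F)c1` differs from compound 2 by trifluoromethyl in place of chloro on an aromatic carbon. For the measured compounds named here, no measured step isolates this change. The nearest guide is a 4.3-fold higher number from compound 1 to compound 3 (0.64 log units; beyond the scatter), which carries the same chloro-to-trifluoromethyl swap together with an amide in place of the urea, and the phenol shared by compounds 2 and 4 costs potency, as shown by a 3.4-fold higher number from compound 1 to compound 2 (0.53 log units; beyond the scatter). Compound 4 is therefore expected to sit close to compound 2, a step of a 1.2-fold higher number from compound 2 to compound 4 (0.09 log units; within the scatter) in this assay, estimated at 13000 nM with a range of 5000 nM to 35000 nM.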

Compound 4, concentration for total growth inhibition: 2500 nM
Beside the measured number, compound 4's estimate is 5.2-fold (0.72 log units) above it; measured number outside the range, below it.
By their numbers in this assay, from the lowest: compounds 4 and 1 (each within the scatter of the next); then compounds 2 and 3 (each within the scatter of the next).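

In this assay the exchange of chloro for trifluoromethyl on the urea aryl ring gives a 4.2-fold lower number from compound 2 to compound 4 (0.63 log units; beyond the scatter) and so lowers the number at this aromatic carbon, ortho to a chloro group, with the rest of compound 2 unchanged. The earlier 4.3-fold higher number from compound 1 to compound 3 (0.64 log units; beyond the scatter) ran the other way, but it also replaced the urea with an amide and so cannot be read as this change alone. Nothing available explains the step.

As far as these compounds go, whether the step holds with the methyl kept on the oxygen remains open, as does how a bromo or a nitrile would fare at this carbon.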